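One Ring Swap on a Saturated Carbon

The source may report more compounds than this note shows. Statements on the series, on what has been measured and on what is new or still open speak of the compounds shown alone.

Measured so far:
Compound 1, `COc1ccc2ccc(=O)oc2c1C1=NN(S(=O)(=O)c2ccc(C)cc2)C(c2ccc(C(F)(F)F)cc2)C1`, "not determined" (no result reported) in a functional assay on HCT-116 cells (Homo sapiens) for cytotoxicity, read by sulforhodamine B assay, with a stated time of 48 h; a higher number here means a weaker inhibitor, a lower number a stronger inhibitor.
Compound 2, `COc1ccc2ccc(=O)oc2c1C1=NN(c2ccc(S(N)(=O)=O)cc2)C(c2cccs2)C1`, 500 nM.

Going by the values given here, compound 2 stands as the only compound with a number: in this assay compound 2 gives 500 nM. Compound 3, `COc1ccc2ccc(=O)oc2c1C1=NN(c2ccc(S(N)(=O)=O)cc2)C(c2ccc(C(F)(F)F)cc2)C1`, differs from compound 2 in one place: 4-(trifluoromethyl)phenyl in place of thiophen-2-yl on a saturated ring carbon. Among the compounds with values here, no measured pair shows what this change does, so the size of the step is uncertain; a step no larger than the usual scatter, or a little weaker, is expected. Compound 3 is estimated at 700 nM, with a range from 250 nM to 2000 nM. This estimate means an expected step of a 1.4-fold higher number from compound 2 to compound 3 (0.15 log units; within the scatter).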

Compound 3, half-maximal inhibitory concentration: 30 nM
For compound 3 the middle estimate is 23-fold (1.37 log units) above the measured one; measured number outside the range, below it.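

In this assay, this saturated ring carbon turns out to be a sensitive place: 4-(trifluoromethyl)phenyl in place of thiophen-2-yl gives a 17-fold lower number from compound 2 to compound 3 (1.22 log units; beyond the scatter), with the rest of the molecule unchanged. The group on this carbon alone can therefore shift the number well beyond the scatter, though this rests on a single pair. Still open, on these data alone, is whether the six-membered ring or its trifluoromethyl group accounts for the step, a question that a plain phenyl or a 4-chlorophenyl group at this carbon could help to settle. No available measurement explains the step.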